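The source may hold more compounds than are shown below. What is called first, only, known or untested is meant among the compounds shown, and "the series" means these compounds.

Measured compounds in a functional assay on ileum for antagonist activity at histamine H1 receptor (Cavia porcellus); on this read-out lower numbers stand for tighter binding and higher numbers for weaker binding:
- compound 1 `COc1ccc(C(CC/N=C(\N)NCCCc2c[nH]cn2)c2ccccn2)cc1` gives 269 nM
- compound 2 `N=C(NCCCc1c[nH]cn1)NCCC(c1ccc(Cl)cc1)c1ccccn1` gives 77.6 nM
- compound 3 `N=C(NCCCc1c[nH]cn1)NCCC(c1ccc(Br)cc1)c1ccccn1` gives 120 nM

Compound 3 stands second highest of the three numbers in this assay. Among the measured compounds shown here, its nearest neighbour is compound 2, and the single counted step between them, a 1.5-fold higher number from compound 2 to compound 3 (0.19 log units; within the scatter), lies within the scatter. For the measured compounds named here, compound 1, with a methoxy group in place of a halogen, sits furthest from compound 3, and its value is beyond the scatter from that of compound 3; no single-site step connects these two, so the pair shows only that the two numbers differ.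

Compound 4 `N=C(NCCCc1c[nH]cn1)NCCC(c1cccc(C(F)(F)F)c1)c1ccccn1` differs from compound 3 in one place: 3-(trifluoromethyl)phenyl in place of 4-bromophenyl on a saturated chain carbon bound to an aromatic carbon and a saturated chain carbon. Going by the values given here, no measured step covers this change. Among the compounds with values here, the only step available, a 1.5-fold higher number from compound 2 to compound 3 (0.19 log units; within the scatter), exchanges one halogen for another on the same aryl ring and does not move the number beyond the scatter. The present change replaces the halogen and also shifts the substituent to the 3-position of the phenyl ring, so the measured step is at best a weak guide, and a wide range is needed.

On that basis the number for compound 4 is expected to stay near that of compound 3, with a 1.3-fold higher number from compound 3 to compound 4 (0.10 log units; within the scatter) as the expected step, so compound 4 is estimated at 150 nM, within 50 nM to 450 nM.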

Compound 4, dissociation constant: 525 nM
The estimate for compound 4 lay 3.5-fold (0.54 log units) below the measured number; the whole stated range lies below it.
By their numbers in this assay, from the lowest: compounds 2 and 3 (each within the scatter of the next); then compounds 1 and 4 (each within the scatter of the next).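

In this assay, the saturated chain carbon bound to an aromatic carbon and a saturated chain carbon proves sensitive to the aryl group it carries: 3-(trifluoromethyl)phenyl in place of 4-bromophenyl gives a 4.4-fold higher number from compound 3 to compound 4 (0.64 log units; beyond the scatter), and 3-(trifluoromethyl)phenyl in place of 4-chlorophenyl gives a 6.8-fold higher number from compound 2 to compound 4 (0.83 log units; beyond the scatter). The only earlier step at this place, the exchange of chloro for bromo on the aromatic carbon with a 1.5-fold higher number from compound 2 to compound 3 (0.19 log units; within the scatter), stayed within the scatter, so these are the first steps shown here to move the number beyond it, both towards weaker binding. No measurement at hand bears on the reason for this rise.

The new group differs from the halogenated aryl groups in both its substituent and that substituent's place on the phenyl ring, and the compounds shown cannot separate these two changes. Going by these compounds, how this assay would read with an unsubstituted phenyl at this carbon, or with a phenyl ring carrying a nitrile or a carboxylic acid, also remains open.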